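Compound 4: a large group on the hydroxyl oxygen

The source may report more compounds than this note shows. Statements on the series, on what has been measured and on what is new or still open speak of the compounds shown alone.

In an ADME assay on HEK293 cells (Homo sapiens) for cytotoxicity, read by CellTiter-Glo, with a stated time of 72 h (a lower number here means that less compound is needed, a higher number that more compound is needed for the effect), compound 2 (`CC1=C2CC(C)(C)/C=C/[C@H](O)/C(C)=C\C3=C[C@H](C)C[C@]3(O2)C1=O`) gives 26000 nM. This is level with compound 1 (`CC1=C2CC(C)(C)[C@@H]3C=C(OC3)/C(C)=C\C3=C[C@H](C)C[C@]3(O2)C1=O`) at 26000 nM and compound 3 (`CC1=C2CC(C)(C)/C=C/[C@@H](O)/C(C)=C\C3=C[C@H](C)C[C@]3(O2)C1=O`) at 26000 nM, so compound 2 stands neither above nor below its two measured neighbours.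

Compound 4 (`CC1=C2CC(C)(C)/C=C/[C@H](OC(=S)Sc3ccccc3)/C(C)=C\C3=C[C@H](C)C[C@]3(O2)C1=O`) carries a group of 9 heavy atoms (7 carbon, 2 sulfur; one six-membered aromatic ring of carbon only) in place of a hydrogen atom, on an oxygen on a saturated carbon. Among the measured compounds shown here, the one measured step in this small set is no change at the digits printed from compound 2 to compound 3 (within the scatter). It is of limited use here, and its reach is narrow given (the fact that compounds 2 and 3 differ only in the configuration as drawn). For the measured compounds named here, it shows that this assay did not respond to that change in configuration, but no measured step replaces the hydrogen on this oxygen, so the size of such a change remains open.

The expectation therefore rests on the flat values around compound 2, with a wide margin, and no shift beyond the scatter is the central expectation. The expected step is a 1.3-fold lower number from compound 2 to compound 4 (0.11 log units; within the scatter). For compound 4 the estimated value is 20000 nM, with an expected range from 6000 nM to 40000 nM.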

Compound 4, half-maximal effective concentration: 26000 nM
Compound 4: the middle estimate sits 1.3-fold (0.11 log units) below what was measured; the range from low to high includes it.
By their numbers in this assay, from the lowest: compounds 1, 2, 3 and 4 (each within the scatter of the next).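

In this assay, exchanging the hydrogen on the hydroxyl oxygen for the large sulfur-containing group gives no change at the digits printed from compound 2 to compound 4 (within the scatter). The earlier pair, compound 2 and compound 3, spoke only to configuration at this carbon, whereas this step shows that a group of 9 heavy atoms, with its six-membered aromatic ring of carbon only, can stand on this oxygen on a saturated carbon with no shift beyond the scatter. Nothing in the data shown accounts for this flat result.

The compounds shown leave open whether a small methyl group, an acetyl group or a chain ending in an amine or a carboxylic acid on this oxygen would move the number beyond the scatter. They also leave open whether the group of compound 4 would read the same on the configuration of compound 3.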